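This account rests on a few compounds, and the source may have more. Where it says the series, first, only, none or still open, it means among the compounds named here.

In a functional assay on MDA-MB-231 cells (Homo sapiens) for inhibition, read by sulforhodamine B assay, with a stated time of 72 h (a higher number here means a weaker inhibitor of growth, a lower number a stronger inhibitor of growth), compound 1 `CNC(=O)/C=C/c1ccncc1-c1ccc2cc[nH]c2c1` gives 7680 nM, and compound 3 `CCOC(=O)/C=C/c1ccncc1-c1ccc2c(ccn2C)c1` gives 10200 nM. Compound 2 `CCOC(=O)/C=C/c1ccncc1-c1ccc2[nH]ccc2c1` gives > 10000 nM, which is a limit of the assay and not a number, and so it stands at the limit of > 10000 nM in this assay, at which 1 of the 3 values shown sits. Compound 4 `O=C(O)/C=C/c1ccncc1-c1ccc2[nH]ccc2c1` differs from compound 2 by one change, (hydrogen in place of ethyl on an oxygen next to a carbonyl group), which turns ethoxycarbonyl into carboxy. Among the measured compounds shown here, the only measured step that starts from compound 2, a step that the limit leaves unreadable from compound 2 to compound 3, puts methyl in place of hydrogen on an aromatic nitrogen. That is a different change, and it offers no size to carry over. No clear shift in either direction is therefore expected, only a step beyond the scatter at most unlikely to show: the expected move is a step that the limit leaves unreadable from compound 2 to compound 4. Compound 4 is estimated at 14000 nM, with an expected range of 5000 nM to 40000 nM.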

Compound 4, concentration for 50% growth inhibition: > 10000 nM
Compound 4: a limit, no number; the forecaster's own chance of this, stated with the estimate: 65%; the middle value does not contradict the limit.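

Compound 2 and compound 4 both end at a limit of the assay rather than a number, so no step between them can be read: the limit of > 10000 nM in this assay, at which 2 of the 4 values shown sit.

The compounds shown leave open whether carboxy in place of ethoxycarbonyl shifts growth inhibition in this assay at all.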